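The compounds below may be only part of what the source reports. "The series", "measured", "known", "first", "only" and "open" are said of these compounds alone.

Measured so far in a functional assay on BGC-823 cells (Homo sapiens) for cytotoxicity, read by CCK-8 assay, with a stated time of 72 h; on this read-out higher numbers stand for weaker inhibition and lower numbers for stronger inhibition:
- compound 1 `C=CCn1c(=O)/c(=C\c2cc(Br)ccc2F)[nH]c(=O)/c1=C\c1ccccc1OC`: "not active" (no number reported) (no number given)
- compound 2 `C=CCn1c(=O)/c(=C\c2ccccc2OC)[nH]c(=O)/c1=C\c1ccccc1OC`: 13400 nM
- compound 3 `C=CCn1c(=O)/c(=C\c2cccc(Br)c2)[nH]c(=O)/c1=C\c1ccccc1OC`: 5900 nM

Compound 3 holds the lowest of the two numbers recorded in this assay; its nearest neighbour is compound 2, and the step of a 2.3-fold lower number from compound 2 to compound 3 (0.36 log units; beyond the scatter) lies beyond the scatter. Compound 1 carries no number, only the statement that it is not active, so it cannot be ranked against the others.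

Compound 4 `C=CCn1c(=O)/c(=C\c2ccc(F)c(Br)c2)[nH]c(=O)/c1=C\c1ccccc1OC` differs from compound 3 by fluoro in place of hydrogen on an aromatic carbon. Among the compounds with values here, no measured step covers this change: the single step known, from compound 2 to compound 3, swaps one whole aryl group for another and says nothing about a fluoro added next to a bromo group. Compound 1, which also combines bromo and fluoro on that aryl ring in a different arrangement, is reported as not active, which counsels some caution. Within the data shown here, on balance, with no direct precedent, no step beyond the scatter is expected; the move a 1.1-fold higher number from compound 3 to compound 4 (0.04 log units; within the scatter) is estimated as roughly flat. For compound 4 the value in this assay is expected to be about 6500 nM, within a range of 2500 nM to 18000 nM.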

Compound 4, half-maximal inhibitory concentration: "not active" (no number reported)
Nothing numeric was reported for compound 4; the estimate stays without a comparison.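

In this assay, within the data shown here, compound 4 gives "not active" (no number reported), so no step from compound 3 can be read. Nothing at hand accounts for this result. The compounds shown leave open how far compound 4 lies from compound 3, which gives 5900 nM.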